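The compounds below may be only part of what the source reports. "The series", "measured", "known", "first", "only" and "open" are said of these compounds alone.

In a functional assay on MCF7 cells (Homo sapiens) for cytotoxicity, read by MTT assay, with a stated time of 48 h (a higher number here means a weaker inhibitor, a lower number a stronger inhibitor), compound 1 `COc1ccc(-c2nc3ccccn3c2C(=O)/C=C\Nc2cnc3ccccc3c2)cc1` gives 15000 nM and compound 2 `COc1ccc(-c2nc3ccccn3c2C(=O)/C=C\Nc2ccc3ncccc3c2)cc1` gives 11600 nM. Among the compounds with values here, these are the only two measurements so far, and they lie within the scatter of each other, so compound 1 stands level with its one neighbour. Within the data shown here, the single measured step, a 1.3-fold lower number from compound 1 to compound 2 (0.11 log units; within the scatter), comes with quinolin-6-yl in place of quinolin-3-yl on an amine nitrogen. Compound 3 `O=C(/C=C\Nc1cnc2ccccc2c1)c1c(-c2ccc(Cl)cc2)nc2ccccn12` keeps the quinolin-3-yl group and differs in another place: chloro in place of methoxy on an aromatic carbon. Put simply, 4-methoxyphenyl becomes 4-chlorophenyl. The measured step does not touch this group, so it offers only a weak guide and no direction. No shift beyond the scatter is therefore expected, and the estimated step is a 1.2-fold lower number from compound 1 to compound 3 (0.06 log units; within the scatter). Compound 3 is expected near 13000 nM, with an estimated range from 4500 nM to 35000 nM.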

Compound 3, half-maximal inhibitory concentration: 18900 nM
Estimate against measurement, compound 3: 1.5-fold (0.16 log units) below, within the range that was stated.
By their numbers in this assay, from the lowest: compounds 2, 1 and 3 (each within the scatter of the next).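

In this assay the change from 4-methoxyphenyl to 4-chlorophenyl comes with a 1.3-fold higher number from compound 1 to compound 3 (0.10 log units; within the scatter) and so gives no readable difference. This position, on an aromatic carbon para to a large group, therefore holds either methoxy or chloro without a measurable shift in this read-out, although methoxy carries one hydrogen-bond acceptor and two heavy atoms while chloro carries no acceptor and one heavy atom. No measured property of these compounds is at hand to bear on this result.

Going by these compounds, whether this position would respond to a quite different group, such as an amine, a carboxylic acid or a longer chain, stays open. Also open, on these data alone, is whether chloro in place of methoxy would give the same result alongside the quinolin-6-yl group of compound 2.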